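Swapping the aryl group on the shared core

The source may hold more compounds than are shown below. What is called first, only, known or untested is meant among the compounds shown, and "the series" means these compounds.

Compound 2 `C=C(Br)C(=O)Nc1cccc(-c2cn3nc(-c4cccc(OC)c4)sc3n2)c1` gives the lowest number of the three measured compounds in a functional assay on HeLa cells (Homo sapiens) for inhibition, read by cell counting, with a stated time of 4 days (on this read-out lower numbers stand for stronger inhibition and higher numbers for weaker inhibition), 1100 nM. Compound 1 `C=C(Br)C(=O)Nc1cccc(-c2cn3nc(-c4ccc(CC)cc4)sc3n2)c1` gives 3200 nM in this assay, and compound 3 `COc1cccc(-c2nn3cc(-c4cccc(N)c4)nc3s2)c1` gives 230000 nM. The step of a 2.9-fold lower number from compound 1 to compound 2 (0.46 log units; beyond the scatter) shows that the choice of aryl group on the shared core moves the number modestly, whereas the step of a 210-fold higher number from compound 2 to compound 3 (2.32 log units; beyond the scatter) shows the large loss when the (1-bromoethenyl)carbonyl group is removed. Compound 4 `C=C(Br)C(=O)Nc1cccc(-c2cn3nc(-c4ccc(Cl)cc4)sc3n2)c1` keeps that group and differs from compound 2 only in the aryl group: 4-chlorophenyl in place of 3-methoxyphenyl on an aromatic carbon. For the measured compounds named here, only the step from compound 1 to compound 2 bears on this change, and compound 4 resembles compound 1 in carrying its substituent at the 4-position. The number for compound 4 in this assay is therefore expected to lie between those of compound 1 and compound 2, a modest rise estimated as a 1.8-fold higher number from compound 2 to compound 4 (0.26 log units; within the scatter). Compound 4 is expected to give about 2000 nM, within a range of 700 nM to 7000 nM.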

Compound 4, half-maximal inhibitory concentration: 3000 nM
Compound 4: middle estimate off by 1.5-fold (0.18 log units), on the low side; the range from low to high includes it.
By their numbers in this assay, from the lowest: compound 2; then compounds 4 and 1 (each within the scatter of the next); then compound 3.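

In this assay, replacing 3-methoxyphenyl with 4-chlorophenyl at this aromatic carbon gives a 2.7-fold higher number from compound 2 to compound 4 (0.44 log units; beyond the scatter), so a second aryl change now leaves compound 2 with the lower number. Chloro in place of ethyl gives a 1.1-fold lower number from compound 1 to compound 4 (0.03 log units; within the scatter), which means that 4-chlorophenyl and 4-ethylphenyl cannot be told apart on this read-out, despite the different groups they carry. No supporting information is available to explain why 3-methoxyphenyl differs from these two aryl groups.

As far as these compounds go, it remains open whether the gap follows the methoxy group itself or the place it holds on the phenyl ring. Also open is how the number would respond to an amine or a carboxylic acid on that ring, since the compounds shown cover only methoxy, ethyl and chloro substituents.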